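The source may hold more compounds than are shown below. What is called first, only, known or untested is meant among the compounds shown, and "the series" means these compounds.

Three compounds were measured in an assay on HEK293 cells for displacement of a labelled ligand from Melanocortin receptor 4 (Homo sapiens); a lower number here means a stronger inhibitor, a higher number a weaker inhibitor:

compound 1, `Cc1ccc(CC(C)C(=O)N2CCN(c3ccc(C(F)(F)F)cc3[C@@H](N)CC(C)C)CC2)cc1C`, gives 240 nM;
compound 2, `CC(C)C[C@H](N)c1cc(C(F)(F)F)ccc1N1CCN(C(=O)CNc2ccccc2)CC1`, gives 3600 nM;
compound 3, `CC(C)C[C@H](N)c1cc(C(F)(F)F)ccc1N1CCN(C(=O)CCC2CCCCC2)CC1`, gives 5700 nM.

Compound 1 holds the lowest number of the three; compound 2 is nearest to it, at a 15-fold higher number from compound 1 to compound 2 (1.18 log units; beyond the scatter), and compound 3 is furthest, at a 24-fold higher number from compound 1 to compound 3 (1.38 log units; beyond the scatter). The two weaker compounds sit close together, at a 1.6-fold higher number from compound 2 to compound 3 (0.20 log units; within the scatter).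

Compound 4, `CC(C)C[C@H](N)c1cc(C(F)(F)F)ccc1N1CCN(C(=O)CSc2ccc(Cl)cc2Cl)CC1`, has not yet been measured in this assay. It differs from compound 1 in one place: ((2,4-dichlorophenyl)sulfanyl)methyl in place of 1-(3,4-dimethylbenzyl)ethyl on a carbonyl carbon. Both measured steps from compound 1 bear on this change, since each replaces the same 1-(3,4-dimethylbenzyl)ethyl group on the carbonyl carbon with a smaller, unbranched chain carrying a ring; both gave large rises in the number, a 15-fold higher number from compound 1 to compound 2 (1.18 log units; beyond the scatter) and a 24-fold higher number from compound 1 to compound 3 (1.38 log units; beyond the scatter). Compound 4 carries a chain of the same kind, with one sulfur and a 2,4-dichlorophenyl ring. A large rise is therefore expected for compound 4 as well, estimated at an 8.3-fold higher number from compound 1 to compound 4 (0.92 log units; beyond the scatter) in this assay, giving an expected value of 2000 nM, within a range from 600 nM to 7000 nM.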

Compound 4, inhibition constant: 1500 nM
Estimate against measurement, compound 4: 1.3-fold (0.12 log units) above; low and high end bracket the measured number.
By their numbers in this assay, from the lowest: compound 1; then compound 4; then compounds 2 and 3 (each within the scatter of the next).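

In this assay the carbonyl carbon's substituent does not behave as a single class of unbranched chains: ((2,4-dichlorophenyl)sulfanyl)methyl still falls short of 1-(3,4-dimethylbenzyl)ethyl, at a 6.3-fold higher number from compound 1 to compound 4 (0.80 log units; beyond the scatter), but it is better than both earlier replacements. It gives a 3.8-fold lower number from compound 3 to compound 4 (0.58 log units; beyond the scatter) and a 2.4-fold lower number from compound 2 to compound 4 (0.38 log units; beyond the scatter), whereas compound 2 and compound 3 lay within the scatter of each other. No measurement shown here explains this difference.

The compounds shown leave open whether the sulfur or the two chlorine atoms account for the gain over compound 2, and whether the branching of compound 1 would add to it. A plain phenyl on the sulfur, an ether oxygen in place of the sulfur, or a methyl branch on the chain carbon would address these questions.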